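The compounds below may be only part of what the source reports. "The series", "measured", "known", "first", "only" and "open" are said of these compounds alone.

Measured compounds in an assay on isolated protein (thoracic aorta, strain Sprague-Dawley) for antagonist activity at Alpha-1D adrenergic receptor (Rattus norvegicus), with a stated time of 20 min; on this read-out lower numbers stand for tighter binding and higher numbers for weaker binding:
compound 1 `COc1ccccc1N1CCN(CCCNC(=O)CCc2c[nH]c3ccccc23)CC1` — 34.7 nM
compound 2 `COc1ccccc1N1CCN(CCCNC(=O)CCCc2c[nH]c3ccccc23)CC1` — 5.13 nM
compound 3 `COc1ccc2[nH]c(C(=O)NCCCN3CCN(c4ccccc4OC)CC3)cc2c1` — 58.9 nM

Compound 3 stands at the top of the three numbers in this assay. Its gap to compound 1 lies within the scatter and cannot be read as a difference; its gap to compound 2 lies beyond the scatter, compound 2 giving the lower number. Within the data shown here, the only measured step is a 6.8-fold lower number from compound 1 to compound 2 (0.83 log units; beyond the scatter), which concerns the chain between the carbonyl and the indole, not a substituent on the fused ring.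

Compound 4 `COc1ccccc1N1CCN(CCCNC(=O)c2cc3cc(Cl)ccc3[nH]2)CC1` differs from compound 3 by chloro in place of methoxy on an aromatic carbon. Among the measured compounds shown here, no measured pair changes a substituent at this place, so nothing measured bears directly on the step. The carbonyl, the chain and the arylpiperazine are unchanged. For the measured compounds named here, with no relevant precedent, the expectation for compound 4 is a number close to that of compound 3, a step of a 1.2-fold lower number from compound 3 to compound 4 (0.07 log units; within the scatter), not beyond the scatter. Compound 4 is therefore estimated at 50 nM, with a range from 15 nM to 170 nM to allow for the unknown effect of the new substituent.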

Compound 4, dissociation constant: 19.5 nM
The estimate for compound 4 lay 2.6-fold (0.41 log units) above the measured number, within the range that was stated.
By their numbers in this assay, from the lowest: compound 2; then compounds 4, 1 and 3 (each within the scatter of the next, the first and the last beyond it).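

In this assay, chloro in place of methoxy on this aromatic carbon, meta to a fused ring and para to a fused ring, gives a 3.0-fold lower number from compound 3 to compound 4 (0.48 log units; beyond the scatter). Among these compounds, this is the first sign that a substituent at this place on the fused system moves the number, since the earlier step concerned only the chain between the carbonyl and the indole. The two groups differ in their heavy atoms and hydrogen-bond acceptors, but a single pair cannot show which of these differences, if any, goes with the step, and no measurement at hand explains it.

The compounds shown leave open how the bare ring carbon, or groups such as fluoro, bromo, methyl or trifluoromethyl, would compare with chloro and methoxy at this place, so the step cannot yet be read as a trend across substituents. Also open, from the compounds shown here alone, is whether chloro at the corresponding place would give a similar step in the chain-extended compounds 1 and 2, whose rings carry no such substituent.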